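Fluorosulfonyloxy for dicyanoethenyl on the chromene core

This account rests on a few compounds, and the source may have more. Where it says the series, first, only, none or still open, it means among the compounds named here.

Measured so far:
compound 1 `CCC(=O)c1ccc2c(c1)C(n1ccccc1=O)=CC(C)(C)O2`, 5.85
compound 2 `CC1(C)C=C(n2ccccc2=O)c2cc(C=C(C#N)C#N)ccc2O1`, 6.3

Both numbers come from a functional assay (trachea) with Rattus norvegicus as the target; on this read-out higher numbers stand for higher potency (the scale is a negative logarithm) and lower numbers for lower potency. Among the compounds with values here, compound 2 holds the higher of the two values; its only neighbour is compound 1, and the step of a number 0.45 log units higher from compound 1 to compound 2 (beyond the scatter) lies beyond the scatter, so compound 2 stands ahead of compound 1 by a modest margin.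

Compound 3 `CC1(C)C=C(n2ccccc2=O)c2cc(OS(=O)(=O)F)ccc2O1` differs from compound 2 in one place: (fluorosulfonyl)oxy in place of 2,2-dicyanoethenyl on an aromatic carbon. Within the data shown here, the single measured step, from compound 1 to compound 2, swaps one substituent for another at the same aromatic carbon, but neither of those groups is the (fluorosulfonyl)oxy group that enters here, so no measured step bears directly on this change. That step was of modest size, which is all the series says about how much a substituent at this position can move this assay.

Among the measured compounds shown here, with no closer precedent, the expectation for compound 3 is no step beyond the scatter, an estimated a number 0.30 log units lower from compound 2 to compound 3 (within the scatter) from compound 2, with a wide range.

Compound 3 is therefore estimated at 6, expected between 5.3 and 6.7.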

Compound 3, logarithm of the reciprocal of the active concentration, log(1/C): 7.22
For compound 3 the middle estimate is 1.22 log units below the measured one; measured number outside the range, above it.
By their numbers in this assay, from the lowest: compound 1; then compound 2; then compound 3.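

In this assay the aromatic carbon carrying the varied group proves more responsive than the first pair suggested: the earlier step was a number 0.45 log units higher from compound 1 to compound 2 (beyond the scatter), whereas (fluorosulfonyl)oxy gives a number 0.92 log units higher from compound 2 to compound 3 (beyond the scatter). Measured against the propanoyl compound, the change is wider still, a number 1.37 log units higher from compound 1 to compound 3 (beyond the scatter), and compound 3 therefore ranks highest of the three, with its steps to both others beyond the scatter. The series thus shows that the choice of substituent on this carbon alone can shift the read-out substantially, though no measurement here accounts for the gain.

With only three substituents, all on the shared core, the compounds shown do not reveal whether the gain depends on the whole (fluorosulfonyl)oxy group or on only part of it, a question that methanesulfonyl, a simple nitrile or a methoxy group on the same carbon could help to answer. As far as these compounds go, how an amine or a carboxylic acid would behave at this carbon also remains open, as does whether the rank order of compound 1, compound 2 and compound 3 holds beyond this single trachea read-out.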